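The source may report more compounds than this note shows. Statements on the series, on what has been measured and on what is new or still open speak of the compounds shown alone.

Within the data shown here, in a functional assay on MDA-MB-468 cells (Homo sapiens) for antiproliferative activity, read by sulforhodamine B assay, with a stated time of 4 days (on this read-out higher numbers stand for weaker inhibition of growth and lower numbers for stronger inhibition of growth), compound 1 (`COc1cc(Cl)c(-c2nc(SCC(=O)NC3CC3)nc3[nH]cc(C#N)c23)cc1OC`) gives 62 nM, the lower of the two numbers so far. Compound 2 (`COc1cc(Cl)c(-c2nc(SCC(=O)NC3CC3)nc3[nH]cc(C#N)c23)cc1O`), which has hydrogen in place of methyl on an oxygen on an aromatic ring, gives 236 nM. Compound 3 (`CNC(=O)CSc1nc(-c2cc(OC)c(OC)cc2Cl)c2c(C#N)c[nH]c2n1`) is unmeasured. It keeps that methyl and differs from compound 1 on the amide instead: methyl in place of cyclopropyl on an amide-type nitrogen. Cyclopropylcarbamoyl thus becomes methylcarbamoyl. Among the measured compounds shown here, no measured step touches this place, so a 3.8-fold higher number from compound 1 to compound 2 (0.58 log units; beyond the scatter) serves only as a rough gauge of step size. A modest move toward a higher number in this assay is expected, probably no larger than that gauge, and it may stay within the scatter. The expected step is a 1.8-fold higher number from compound 1 to compound 3 (0.25 log units; within the scatter). Compound 3 is estimated at 110 nM, with a range from 40 nM to 320 nM.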

Compound 3, concentration for 50% growth inhibition: 33 nM
The estimate for compound 3 lay 3.3-fold (0.52 log units) above the measured number; measured number below the stated range.
By their numbers in this assay, from the lowest: compounds 3 and 1 (each within the scatter of the next); then compound 2.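

In this assay, replacing cyclopropyl with methyl on the amide-type nitrogen gives a 1.9-fold lower number from compound 1 to compound 3 (0.27 log units; within the scatter). For this pair, the three-membered ring is therefore not required to keep the number in the range of compound 1, and the smaller methyl serves equally well within the scatter. This position is so far less sensitive than the aromatic oxygen, where the step is a 3.8-fold higher number from compound 1 to compound 2 (0.58 log units; beyond the scatter) and lies beyond the scatter, and no measurement available here explains the result.

Still open, going by these compounds, is how far this tolerance extends on the amide-type nitrogen, for example to a plain hydrogen, a longer chain such as butyl, or a chain ending in an amine or a carboxylic acid. Also open, on these data alone, is whether hydrogen in place of methyl on the aromatic oxygen would give a comparable step in the methylcarbamoyl compound.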